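Swapping an open-chain acid for a cyclic ester amide

The source may report more compounds than this note shows. Statements on the series, on what has been measured and on what is new or still open speak of the compounds shown alone.

Measured compounds:
- compound 1, `CC(C)(C)c1ccc(C(=O)N2CCC3(CC2)C(=O)N(CC(=O)NCCC(=O)O)CN3c2ccccc2)cc1`: 11400 nM
- compound 2, `O=C(CN1CN(c2ccccc2)C2(CCN(C(=O)c3ccc(C4CCCCC4)cc3)CC2)C1=O)N1CCCCC1`: 1100 nM
- compound 3, `CC1CCCN(C(=O)CN2CN(c3ccccc3)C3(CCN(C(=O)c4ccc(C5CCCCC5)cc4)CC3)C2=O)C1`: 3600 nM

In an assay on HEK293 cells for displacement of a labelled ligand from NPC1-like intracellular cholesterol transporter 1 (Homo sapiens) (on this read-out lower numbers stand for stronger inhibition and higher numbers for weaker inhibition), compound 1 gives the highest of the three numbers: compound 3 sits below it and compound 2 lower still. Compound 4, `CCOC(=O)C1CCN(C(=O)CN2CN(c3ccccc3)C3(CCN(C(=O)c4ccc(C(C)(C)C)cc4)CC3)C2=O)CC1`, has not yet been measured. It keeps the shared core and the tert-butyl-bearing aryl amide of compound 1 and changes one place: 4-(ethoxycarbonyl)piperidin-1-yl in place of (2-carboxyethyl)amino on a carbonyl carbon.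

For the measured compounds named here, the only measured step, a 3.3-fold higher number from compound 2 to compound 3 (0.51 log units; beyond the scatter), concerns a methyl on the ring of a cyclic amide and does not touch the change from compound 1 to compound 4. What compounds 2 and 3 do show is that cyclic amides at this carbonyl carbon can go with lower numbers than the open-chain acid of compound 1, though both also carry a different aryl group, so the comparison is not clean. A lower number for compound 4 is therefore expected, of modest size, as a 3.3-fold lower number from compound 1 to compound 4 (0.51 log units; beyond the scatter). Compound 4 is estimated at 3500 nM, with a range from 1200 nM to 10000 nM.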

Compound 4, half-maximal inhibitory concentration: 3100 nM
Beside the measured number, compound 4's estimate is 1.1-fold (0.05 log units) above it; low and high end bracket the measured number.
By their numbers in this assay, from the lowest: compound 2; then compounds 4 and 3 (each within the scatter of the next); then compound 1.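

For the compounds shown here, compounds 1 and 4 share the core and the tert-butyl-bearing aryl amide, so this is the first comparison that isolates the group on this carbonyl carbon. In this assay, the swap gives a 3.7-fold lower number from compound 1 to compound 4 (0.57 log units; beyond the scatter), which shows that this position accepts a much larger group with a ring: 11 heavy atoms in place of 6, and the number still falls rather than rises. The change is not a single feature, however, since a six-membered ring enters, the free acid gives way to an ethyl ester and the 2 hydrogen-bond donors of the (2-carboxyethyl)amino group are lost, and nothing available here shows which of these matters or explains the step.

Still open, going by these compounds, is whether the ring or the ester carries the difference: a piperidine bearing a free carboxylic acid in place of the ethyl ester, on the same tert-butyl-bearing aryl amide, would separate the two. Also open, on these data alone, is how an ester-free, unsubstituted piperidine or a ring bearing a primary amine would read at this carbonyl carbon with that aryl amide.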